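Replacing (hex-5-en-1-yl)oxy in compound 1 with phenylsulfonyl

The source may hold more compounds than are shown below. What is called first, only, known or untested is meant among the compounds shown, and "the series" means these compounds.

In a functional assay on T98G cells (Homo sapiens) for inhibition, read by colorimetric assay and MTT assay, with a stated time of 72 h (a higher number here means a weaker inhibitor, a lower number a stronger inhibitor), compound 1 `C=CCCCCOc1ccccc1-c1cnc(OCCCCC=C)n1C` gives 4000 nM and compound 2 `C=CCCCCOc1ncc(-c2ccccc2OC)n1C` gives 5000 nM, so the two stand level, while compound 3 `C=CCCCCOc1ncc(-c2cc(C(F)(F)F)ccc2OC)n1C` lies well apart at 88000 nM. Compound 1 therefore belongs to the more potent pair of the three measured compounds, without being separable from its partner. Hydrogen in place of pent-4-en-1-yl is a 1.3-fold higher number from compound 1 to compound 2 (0.10 log units; within the scatter). Trifluoromethyl in place of hydrogen on an aromatic carbon is an 18-fold higher number from compound 2 to compound 3 (1.25 log units; beyond the scatter).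

The next change leads to compound 4 `C=CCCCCOc1ccccc1-c1cnc(S(=O)(=O)c2ccccc2)n1C`: phenylsulfonyl in place of (hex-5-en-1-yl)oxy on an aromatic carbon. Here phenylsulfonyl stands in place of (hex-5-en-1-yl)oxy on an aromatic carbon of the five-membered ring. All three measured compounds keep (hex-5-en-1-yl)oxy at that carbon, so neither measured step tests this place, and both bear on it only loosely. With no direct evidence, the working expectation is no step beyond the scatter, with a slight lean towards a higher number. The range stays wide because an 18-fold higher number from compound 2 to compound 3 (1.25 log units; beyond the scatter) shows that one change elsewhere on the molecule can be large. Compound 4 is estimated at 6000 nM, with an expected range of 1200 nM to 30000 nM. This estimate amounts to a 1.5-fold higher number from compound 1 to compound 4 (0.18 log units; within the scatter).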

Compound 4, half-maximal inhibitory concentration: 71000 nM
Compound 4: the middle estimate sits 12-fold (1.07 log units) below what was measured; measured number above the stated range.
By their numbers in this assay, from the lowest: compounds 1 and 2 (each within the scatter of the next); then compounds 4 and 3 (each within the scatter of the next).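

In this assay, for the compounds shown here, this is the first reading of the aromatic carbon between two ring nitrogen atoms, and phenylsulfonyl in place of (hex-5-en-1-yl)oxy gives an 18-fold higher number from compound 1 to compound 4 (1.25 log units; beyond the scatter) in a single change. This carbon therefore joins the aromatic carbon that takes trifluoromethyl in an 18-fold higher number from compound 2 to compound 3 (1.25 log units; beyond the scatter) as a place where one change moves the number beyond the scatter, unlike the loss of pent-4-en-1-yl in a 1.3-fold higher number from compound 1 to compound 2 (0.10 log units; within the scatter), which stays within it. Nothing in the data accounts for the size of this step at the five-membered ring.

On these data alone, whether the higher number follows the sulfonyl link, the added phenyl ring or the loss of the hexenyl chain remains open, as all three changes arrive together in compound 4. A phenoxy group, a methylsulfonyl group or an amine at this same carbon would begin to separate those parts, and a shorter alkoxy chain such as methoxy would show how much of the chain this carbon needs.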